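Ester alkyl swap in the thienyl series

A few compounds are considered here, and "the series" means these few. Any claim that something is new, unique, unknown or untested is made for them only; others in the source may bear on it.

Compound 3 `CCC(C)OC(=O)C1=C(C)NC(=O)NC1c1cccs1` gives 5% in an assay on membranes from CHO cells for displacement of a labelled ligand from adenosine receptor A1 (Homo sapiens), read by scintillation counting, with a stated time of 60 min, tested at 1 uM; a lower number here means less inhibition, a higher number more inhibition at the concentration tested (going by the name of the read-out). Compound 2 `CCSC(=O)C1=C(C)NC(=O)NC1c1cccs1` gives 6% and compound 1 `CCN(CC)C(=O)C1=C(C)NC(=O)NC1c1cccs1` gives 13%; the steps of a number 8 percentage points lower from compound 1 to compound 3 (within the scatter) and a number 1 percentage points lower from compound 2 to compound 3 (within the scatter) both lie within the scatter, so the three readings cannot be separated and all sit at the weak end of what this assay reports.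

Compound 4 `CC1=C(C(=O)OC2CCC2)C(c2cccs2)NC(=O)N1` differs from compound 3 in one place: cyclobutyl in place of sec-butyl on an oxygen next to a carbonyl group. The measured steps all touch the group on the carbonyl carbon: a number 7 percentage points lower from compound 1 to compound 2 (within the scatter), a number 8 percentage points lower from compound 1 to compound 3 (within the scatter) and a number 1 percentage points lower from compound 2 to compound 3 (within the scatter), each within the scatter. Among the compounds with values here, none of them exchanges one alkyl group for another on the ester oxygen, so the change to compound 4 has no direct precedent; the nearest guide is the step from compound 2 to compound 3, where the oxygen-bound group entered and the reading stayed flat.

Given that every change at this position so far left the number within the scatter, compound 4 is expected to read close to compound 3, with an expected step of no change at the digits printed from compound 3 to compound 4 (within the scatter), meaning no change beyond the scatter. The estimate for compound 4 is 5%, with a range from 0% to 13%.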

Compound 4, a percentage reported as inhibition, at one concentration (the size of the read-out at that concentration, not a potency): 24%
Compound 4: middle estimate off by 19 percentage points, on the low side; the whole stated range lies below it.
By their numbers in this assay, from the lowest: compounds 3, 2 and 1 (each within the scatter of the next); then compound 4.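

On the ester oxygen the identity of the alkyl group does matter in this assay: sec-butyl and cyclobutyl both hold 4 carbon atoms, yet the ring gives a number 19 percentage points higher from compound 3 to compound 4 (beyond the scatter) and the earlier exchanges on the carbonyl carbon all stayed within the scatter. The cyclobutyloxy group also separates from the other groups on that carbonyl carbon, with a number 18 percentage points higher from compound 2 to compound 4 (beyond the scatter) and with a number 11 percentage points higher from compound 1 to compound 4 (beyond the scatter) as well, so this position can move the reading, though only modestly and at one concentration. No supporting evidence is available to explain the rise.

Going by these compounds, whether any ring on this oxygen would do the same, or only the four-membered one, remains open; cyclopropyl and cyclopentyl esters would address that. An unbranched n-butyl ester would show how much of the step depends on losing the sec-butyl branch.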